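Swapping nitro for amino in compound 2

The compounds below may be only part of what the source reports. "The series", "measured", "known", "first", "only" and "open" are said of these compounds alone.

In a functional assay on A549 cells (Homo sapiens) for inhibition (on this read-out lower numbers stand for stronger inhibition and higher numbers for weaker inhibition), compound 2 `COc1cc(/C=C/c2ccc(N(C)C)c([N+](=O)[O-])c2)cc(OC)c1OC` reports only a limit, > 5000 nM. Compound 3 `COc1cc(/C=C\c2ccc(N(C)C)c([N+](=O)[O-])c2)cc(OC)c1OC` also reports only a limit, > 5000 nM. Together these two give a step that the two limits leave unreadable from compound 2 to compound 3, so this step offers no size to carry forward, and it concerns the fact that compounds 2 and 3 differ only in the configuration as drawn rather than the nitro group.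

The change to follow replaces nitro with amino on an aromatic carbon, ortho to a dimethylamino group, and gives compound 4 `COc1cc(/C=C/c2ccc(N(C)C)c(N)c2)cc(OC)c1OC`: amino in place of nitro on an aromatic carbon. Within the data shown here, no measured step covers this swap directly. The nearest guide is compound 1 `COc1ccc(/C=C/c2ccc3ccccc3c2)cc1N`, which has a different core but also carries an amino group on an aromatic carbon, and it gives a true number, 1820 nM. On that single, thin comparison, some measurable inhibition is expected after the swap. The expected change is an at least 2.0-fold lower number from compound 2 to compound 4 (0.30 log units; that floor lies within the scatter), towards stronger inhibition, though it could still fall short of a readable value. For compound 4 the estimate is 2500 nM, with an expected range of 600 nM to 10000 nM.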

Compound 4, half-maximal inhibitory concentration: 1520 nM
Estimate against measurement, compound 4: 1.6-fold (0.22 log units) above; the range from low to high includes it.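

In this assay, the swap of nitro for amino on an aromatic carbon, ortho to a dimethylamino group, gives a step that can be read at this position: an at least 3.2-fold lower number from compound 2 to compound 4 (0.51 log units; beyond the scatter). Going by these compounds, the earlier pair offered no such reading, as its step cannot be read and it concerns a different kind of change: the fact that compounds 2 and 3 differ only in the configuration as drawn Compound 2 reports only a limit, > 5000 nM, so the printed step is a floor and its true size stays unknown.

This single pair does not show whether amino itself matters here or whether another group in this place, such as a hydroxyl or an acetamide, would give a similar step. It also gives no reason for the step and sets no pattern beyond compound 2 and compound 4.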